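Adding a Fluorine to a Weakly Cytotoxic Series

The source may hold more compounds than are shown below. What is called first, only, known or untested is meant among the compounds shown, and "the series" means these compounds.

Of the compounds shown here, three sharing one core have been tested in a functional assay on HepG2 cells (Homo sapiens) for cytotoxicity, read by MTT assay, with a stated time of 72 h; a lower number here means a stronger inhibitor, a higher number a weaker inhibitor. Compound 1 `Cn1ccc2c(Oc3ccc(NC(=O)c4nn(-c5ccc(Br)cc5)ccc4=O)cc3)ccnc21` gives 39200 nM. Compound 2 `Cn1ccc2c(Oc3ccc(NC(=O)c4nn(-c5ccc(Br)cc5F)ccc4=O)cc3)ccnc21`, which carries a fluoro in place of hydrogen on an aromatic carbon, gives 31200 nM, and the step of a 1.3-fold lower number from compound 1 to compound 2 (0.10 log units; within the scatter). Compound 3 `Cn1ccc2c(Oc3ccc(NC(=O)c4nn(-c5ccc(Cl)c(C(F)(F)F)c5)ccc4=O)cc3)ccnc21` gives 23400 nM; its number is the lowest of the three, but the steps of a 1.7-fold lower number from compound 1 to compound 3 (0.22 log units; within the scatter) and a 1.3-fold lower number from compound 2 to compound 3 (0.12 log units; within the scatter) both remain within the scatter, so no ordering among these compounds can be claimed.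

Compound 4 `Cn1ccc2c(Oc3ccc(NC(=O)c4nn(-c5ccc(Cl)c(C(F)(F)F)c5)ccc4=O)cc3F)ccnc21` differs from compound 3 by fluoro in place of hydrogen on an aromatic carbon, a hydrogen replaced by one fluorine placed on an aromatic carbon of a six-membered aromatic ring of carbon only, ortho to a large group and meta to a large group. Within the data shown here, the only measured step of the same kind, from compound 1 to compound 2, sits on a different ring and was a 1.3-fold lower number from compound 1 to compound 2 (0.10 log units; within the scatter). Nothing in the three measured compounds therefore points to a step beyond the scatter for this change.

Compound 4 is accordingly expected to give about 20000 nM in this assay, with a likely range from 8000 nM to 50000 nM, which means an expected step of a 1.2-fold lower number from compound 3 to compound 4 (0.07 log units; within the scatter).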

Compound 4, half-maximal inhibitory concentration: 13500 nM
For compound 4 the middle estimate is 1.5-fold (0.17 log units) above the measured one; low and high end bracket the measured number.
By their numbers in this assay, from the lowest: compounds 4, 3, 2 and 1 (each within the scatter of the next, the first and the last beyond it).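

Compound 4 extends the fluoro change to a new place, an aromatic carbon of a six-membered aromatic ring of carbon only, ortho to a large group and meta to a large group, and in this assay the result is a 1.7-fold lower number from compound 3 to compound 4 (0.24 log units; within the scatter). Among these compounds, the earlier compounds showed this change only on the other aryl ring, so this is the first reading for this position, and it shows that a fluoro here, on the core of compound 3, leaves the number within the scatter of the hydrogen. The change has now been read on two cores and at two places, and the two readings agree: the same change on two cores in this assay, a 1.3-fold lower number (0.10 log units; within the scatter) from compound 1 to compound 2 and a 1.7-fold lower number (0.24 log units; within the scatter) from compound 3 to compound 4, 1.4-fold (0.14 log units) apart, within the scatter of two such steps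

Whether a chloro, a methoxy, a hydroxyl or an amine on this same carbon would give a step beyond the scatter stays open, since fluoro is the only group shown replacing hydrogen there. All four numbers also come from this assay, and how this step reads on any other cells, or what the compounds do at the much lower concentrations of a target-based test, remains unanswered.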